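A Second Chloro Group Tested on Two Related Cores

The source may hold more compounds than are shown below. What is called first, only, known or untested is meant among the compounds shown, and "the series" means these compounds.

Measured compounds:
Compound 1, `Cc1ncc([N+](=O)[O-])n1CC(O)CSC(=S)N1CCN(c2cccc(Cl)c2)CC1`, gives 1080000 nM in a toxicity assay on HeLa cells (Homo sapiens) for cytotoxicity, read by MTT assay, with a stated time of 24 h; on this read-out lower numbers stand for stronger inhibition and higher numbers for weaker inhibition.
Compound 2, `Cc1ncc([N+](=O)[O-])n1CC(O)CSC(=S)N1CCN(c2cccc(Cl)c2Cl)CC1`, gives 1000000 nM in this assay.
Compound 3, `Cc1ncc([N+](=O)[O-])n1CC(O)CN1CCN(c2cccc(Cl)c2)CC1`, gives 1440000 nM in this assay.

For the measured compounds named here, compound 1 and compound 2 share one core, and the single change between them is chloro in place of hydrogen on an aromatic carbon. That change gave a 1.1-fold lower number from compound 1 to compound 2 (0.03 log units; within the scatter), so the second chloro group left the read-out essentially where it was. Compound 3 carries a different core; how it differs from compound 1 is not broken down here. Its value and that of compound 1 lie within the usual scatter of each other, as do its value and that of compound 2, so the three measured compounds cannot be ranked against one another on this read-out.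

Compound 4, `Cc1ncc([N+](=O)[O-])n1CC(O)CN1CCN(c2cccc(Cl)c2Cl)CC1`, is not yet measured. It arises from compound 3 by chloro in place of hydrogen on an aromatic carbon, the same change that turned compound 1 into compound 2, in the same place on the ring. Because the earlier step was a 1.1-fold lower number from compound 1 to compound 2 (0.03 log units; within the scatter), the step from compound 3 to compound 4 is expected to be small as well, a 1.1-fold lower number from compound 3 to compound 4 (0.04 log units; within the scatter), with the new core taken as behaving like the old one for this change. Compound 4 is therefore estimated at 1300000 nM in this assay, most likely between 650000 nM and 2600000 nM.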

Compound 4, half-maximal inhibitory concentration: > 5000000 nM
Compound 4 gave a limit, no number (the forecaster's own chance of this, stated with the estimate: 15%); middle value at least 3.8-fold (0.58 log units) away from the limit.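

On the second core, the change from 3-chlorophenyl to 2,3-dichlorophenyl gave an at least 3.4-fold higher number from compound 3 to compound 4 (0.54 log units; beyond the scatter), and a higher number here stands for weaker inhibition, so the small step seen on the core of compound 1 did not carry over in this assay: the same change on two cores in this assay, a 1.1-fold lower number (0.03 log units; within the scatter) from compound 1 to compound 2 and an at least 3.4-fold higher number (0.54 log units; beyond the scatter) from compound 3 to compound 4, at least 3.7-fold (0.57 log units) apart, beyond the scatter of two such steps. Compound 4 gives > 5000000 nM, which is a limit of the assay and not a number: the limit of > 5000000 nM in this assay, at which 1 of the 4 values shown sits. For the compounds shown here, this shows that the effect of a change on one core cannot simply be assumed for another core, but with only one pair on each core it does not show why the two steps differ or how large the second step really is.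

The compounds shown carry only chloro groups on the aromatic ring, so it remains open whether another group in that place, such as a methyl or a methoxy group, would also behave differently on the two cores. On these data alone, it is also open whether the same split would appear with an amine in place of the hydroxyl group or with a longer chain linking the two halves of the molecule.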